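A few compounds are considered here, and "the series" means these few. Any claim that something is new, unique, unknown or untested is made for them only; others in the source may bear on it.

Measured so far in an ADME assay on a cell-free system (plasma, Rattus norvegicus, strain Sprague-Dawley) for metabolic stability, read by LC-MS, tested at 1 uM; a higher number here means that the compound lasts longer, a lower number that the compound disappears faster:

- Compound 1, `CC(=O)OCC1CN(S(=O)(=O)c2ccc(F)cc2)CCN1C(C)=O`, gives 0.5 h in this assay.
- Compound 2, `CC(=O)OCC1CN(C(C)=O)CCN1S(=O)(=O)c1ccc(F)cc1`, gives 0.483 h in this assay.
- Compound 3, `COCC1CN(S(=O)(=O)c2ccc(F)cc2)CCN1C(C)=O`, gives in this assay a value reported only as a limit of the assay, >= 4 h.

Compound 1 and compound 2 are built from the same atoms joined differently; the difference between the two cores is not broken down here. Their values in this assay lie within the scatter of each other, so nothing separates them.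

From compound 1 to compound 3 the change is methyl in place of acetyl on an oxygen on a saturated carbon, and it brings an at least 8.0-fold higher number from compound 1 to compound 3 (0.90 log units; beyond the scatter). The number for compound 3 sits at the limit of >= 4 h in this assay, at which 1 of the 3 values shown sits, so the true size of that step is known only as a lower bound.

Compound 4, `COCC1CN(C(C)=O)CCN1S(=O)(=O)c1ccc(F)cc1`, is not yet measured. Among the compounds with values here, it differs from compound 2 by methyl in place of acetyl on an oxygen on a saturated carbon, which is the same change as the one from compound 1 to compound 3, at a place described in the same words.

For compound 4 in this assay the expected step is a 7.2-fold higher number from compound 2 to compound 4 (0.86 log units; beyond the scatter), an estimate that rests on the step seen from compound 1 to compound 3, an at least 8.0-fold higher number from compound 1 to compound 3 (0.90 log units; beyond the scatter), applied to the value of compound 2, 0.483 h. On that basis compound 4 is estimated at 3.5 h, with a range from 1.2 h to 8 h, and a real chance that the assay again reports only a limit rather than a number.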

Compound 4, half-life in the plasma assay: >= 4 h
Compound 4 ended at the assay's limit; the forecaster's own chance of this, stated with the estimate: 45%; middle value at least 1.1-fold (0.05 log units) away from the limit.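

In the plasma assay, replacing acetyl with methyl on the oxygen gives an at least 8.2-fold higher number from compound 2 to compound 4 (0.91 log units; beyond the scatter), and the change has now been seen on both cores: the same change on two cores in the plasma assay, an at least 8.0-fold higher number (0.90 log units; beyond the scatter) from compound 1 to compound 3 and an at least 8.2-fold higher number (0.91 log units; beyond the scatter) from compound 2 to compound 4; the limit leaves it open whether they differ

The change therefore carries over from one core to the other in direction, with a step beyond the scatter each time, but its size on either core remains unknown, since both methoxymethyl compounds stop at a limit of the plasma assay rather than at a number: the limit of >= 4 h in the plasma assay, at which 2 of the 4 values shown sit.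

The pair also offers no readable step in a physicochemical assay for metabolic stability, read by LC-MS, in phosphate buffer, tested at 1 uM (on this read-out lower numbers stand for a shorter-lived compound and higher numbers for a longer-lived compound), where compound 2 and compound 4 both reach a limit, so this read-out cannot show whether the change matters there: the limit of >= 4 h in the physicochemical assay, at which 2 of the 2 values shown sit. In the physicochemical assay compound 2 gives >= 4 h, which is a limit of the assay. In the physicochemical assay compound 4 gives >= 4 h, which is also a limit of the assay.

The compounds shown leave open how long compound 3 and compound 4 really last in the plasma assay, and so whether one core gains more from the change than the other. They also leave open whether the gain would hold with a longer chain such as ethyl on that oxygen, or with an amine or a carboxylic acid in place of the methoxy group.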